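The compounds below may be only part of what the source reports. "The series", "measured", "known", "first", "only" and "open" are said of these compounds alone.

Three compounds share one core and differ only in the group on an aromatic carbon of the five-membered ring: compound 1 `CCOC(=O)c1cn(C(c2ccccc2)c2cc3cc(Br)ccc3nc2OC)nn1`, compound 2 `CCCc1cn(C(c2ccccc2)c2cc3cc(Br)ccc3nc2OC)nn1` and compound 3 `COc1nc2ccc(Br)cc2cc1C(c1ccccc1)n1cc(-c2ccc(F)cc2)nn1`. In an ADME assay on PC-3 cells (Homo sapiens) for cytotoxicity, read by sulforhodamine B assay, with a stated time of 48 h, tested at 10 uM (a higher number here means more inhibition at the concentration tested (going by the name of the read-out), a lower number less inhibition), compound 1 gives 16.1%. Compound 2 gives 8.3%, and compound 3 gives 16.4%. Compound 2 shows the lowest of the three numbers, yet the steps of a number 7.8 percentage points lower from compound 1 to compound 2 (within the scatter) and a number 8.1 percentage points higher from compound 2 to compound 3 (within the scatter) are both within the scatter, so nothing separates the three. Compound 4 `COc1nc2ccc(Br)cc2cc1C(c1ccccc1)n1cc(C2CC2)nn1` carries the change (cyclopropyl in place of propyl on an aromatic carbon). For the measured compounds named here, no measured step swaps these two groups, but every change at this carbon, including a number 0.3 percentage points higher from compound 1 to compound 3 (within the scatter), stayed within the scatter, so the expected step of a number 2.7 percentage points higher from compound 2 to compound 4 (within the scatter) is small. Compound 4 is therefore estimated at 11%, ranging from 0% to 24%.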

Compound 4, a percentage reported as inhibition, at one concentration (the size of the read-out at that concentration, not a potency): 22.6%
The estimate for compound 4 lay 11.6 percentage points below the measured number, and the stated range covers the measured number.
By their numbers in this assay, from the lowest: compounds 2, 1, 3 and 4 (each within the scatter of the next, the first and the last beyond it).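

In this assay this carbon gives its first step beyond the scatter, a number 14.3 percentage points higher from compound 2 to compound 4 (beyond the scatter), and that step swaps propyl for cyclopropyl, two groups with the same count of heavy atoms, of which only cyclopropyl has a ring. The steps of a number 6.2 percentage points higher from compound 3 to compound 4 (within the scatter) and a number 6.5 percentage points higher from compound 1 to compound 4 (within the scatter) stay within the scatter, so compound 4 stands apart from compound 2 only. Nothing measured here explains this step. From the compounds shown here alone, whether cyclobutyl, an amine or a carboxylic acid at this carbon would give a number beyond that of compound 4 stays open.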